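The compounds below may be only part of what the source reports. "The series", "measured", "known", "first", "only" and "open" are said of these compounds alone.

Measured compounds:
Compound 1 `COc1cc2ncnc(NCc3cccc(NC(=O)Nc4ccc(C(C)(C)C)cc4)c3)c2cc1OC` – 5210 nM
Compound 2 `COc1cc2ncnc(NCc3cccc(NC(=O)Nc4ccccc4F)c3)c2cc1OC` – 23800 nM

Among the compounds with values here, in a functional assay on A549 cells (Homo sapiens) for antiproliferative activity, read by MTT assay (on this read-out lower numbers stand for stronger inhibition and higher numbers for weaker inhibition), compound 2 gives the higher of the two numbers measured; its nearest neighbour is compound 1, and the one step recorded, a 4.6-fold higher number from compound 1 to compound 2 (0.66 log units; beyond the scatter), lies beyond the scatter. Compound 3 `COc1cc2ncnc(NCc3cccc(NC(=O)Nc4cccc(C(F)(F)F)c4)c3)c2cc1OC` is not yet measured in this assay. It differs from compound 2 by 3-(trifluoromethyl)phenyl in place of 2-fluorophenyl on an amide-type nitrogen. Within the data shown here, only the step from compound 1 to compound 2 bears on this change, and it shows that the group on the amide-type nitrogen shifts the number by a modest but real amount. Among the measured compounds shown here, because a 4.6-fold higher number from compound 1 to compound 2 (0.66 log units; beyond the scatter) placed the 2-fluorophenyl compound at the weaker end, a further change on that nitrogen is expected to move the number back toward that of compound 1, though the data give no direct pair to fix the size. Compound 3 is therefore estimated at 9000 nM (range 2500 nM to 30000 nM), which is expected to be a step of a 2.6-fold lower number from compound 2 to compound 3 (0.42 log units; beyond the scatter).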

Compound 3, half-maximal inhibitory concentration: 35300 nM
For compound 3 the middle estimate is 3.9-fold (0.59 log units) below the measured one; measured number above the stated range.
By their numbers in this assay, from the lowest: compound 1; then compounds 2 and 3 (each within the scatter of the next).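

In this assay, putting 3-(trifluoromethyl)phenyl in place of 2-fluorophenyl on the amide-type nitrogen gives a 1.5-fold higher number from compound 2 to compound 3 (0.17 log units; within the scatter), so these two groups cannot be told apart on this read-out, although they differ in their substituent and in heavy-atom count. The 4-(tert-butyl)phenyl group now stands apart from both fluorine-bearing groups, with a 6.8-fold higher number from compound 1 to compound 3 (0.83 log units; beyond the scatter) alongside the earlier 4.6-fold higher number from compound 1 to compound 2 (0.66 log units; beyond the scatter), which makes compound 1 the strongest inhibitor of the three. Nothing available explains these differences.

As far as these compounds go, the three phenyl groups differ in both the substituent and its printed position, so the separate contribution of each remains open. Also open, from the compounds shown here alone, is how an amine or a carboxylic acid on the phenyl ring, or a longer alkyl chain, would affect the number.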